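Aryl-piperazine swap on an oxazole series: predicting compound 4

A few compounds are considered here, and "the series" means these few. Any claim that something is new, unique, unknown or untested is made for them only; others in the source may bear on it.

Measured compounds:
- compound 1 `CCCc1nc(-c2ccccc2)c(CNCCCN2CCN(c3ccccc3C(F)(F)F)CC2)o1`: 45%
- compound 2 `CCCc1nc(-c2ccccc2)c(CNCCN2CCN(c3cccc(C)c3C)CC2)o1`: 66.7%
- compound 3 `CCCc1nc(-c2ccccc2)c(CNCCCN2CCN(c3ccccc3Cl)CC2)o1`: 64.7%

In an assay on HEK293 cells for inhibition of Voltage-dependent T-type calcium channel subunit alpha-1G (Homo sapiens), read by fluorescence, tested at 10 uM (a higher number here means more inhibition at the concentration tested (going by the name of the read-out), a lower number less inhibition), compound 2 gives 66.7%, the highest of the three numbers. Its nearest neighbour is compound 3 with 64.7%, a gap within the scatter, so the two cannot be ranked. Compound 1, with 45%, sits clearly lower. The only single-change step shown is a number 19.7 percentage points higher from compound 1 to compound 3 (beyond the scatter).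

Compound 4 `CCCc1nc(-c2ccccc2)c(CNCCN2CCN(c3cccc(F)c3)CC2)o1` differs from compound 2 in one place: 3-fluorophenyl in place of 2,3-dimethylphenyl on an amine nitrogen in a ring. Among the compounds with values here, no measured step exchanges one aryl group for another on this ring nitrogen, and the one step that is known concerns a different change on compounds with a different chain, so it offers no direct guide. With no evidence that this swap helps, a small loss relative to compound 2 is expected, possibly within the scatter. For compound 4 the estimate is 55%, with a range from 35% to 75%. The expected step is a number 11.7 percentage points lower from compound 2 to compound 4 (beyond the scatter).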

Compound 4, a percentage reported as inhibition, at one concentration (the size of the read-out at that concentration, not a potency): 62.3%
Estimate against measurement, compound 4: 7.3 percentage points below; the range from low to high includes it.
By their numbers in this assay, from the lowest: compound 1; then compounds 4, 3 and 2 (each within the scatter of the next).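

On an amine nitrogen in a ring, 3-fluorophenyl in place of 2,3-dimethylphenyl gives a number 4.4 percentage points lower from compound 2 to compound 4 (within the scatter) in this assay, the first step shown that exchanges one aryl group for another at this position. For this pair on this chain, the assay therefore does not separate the two groups, so this change of aryl group leaves the read-out within its usual scatter. Nothing available gives a reason for this result.

Still open, going by these compounds, is whether an aryl group carrying a carboxylic acid or an amine would also read close to compound 2. On these data alone, it is also open whether 3-fluorophenyl would give a similar result on the longer chain of compound 3, where the aryl group is a different one.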